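Piperidine amine variation in a tryptamine series, efficacy read-out

This account rests on a few compounds, and the source may have more. Where it says the series, first, only, none or still open, it means among the compounds named here.

Three compounds of one shared core have been run in a functional assay on CHO cells for activation of 5-hydroxytryptamine receptor 1D (Homo sapiens), read by GTPgammaS binding; a lower number here means a smaller maximal response, a higher number a larger maximal response. Compound 1 `O=S(=O)(NCC1CCN(CCCc2c[nH]c3ccc(-n4cnnc4)cc23)CC1)c1ccccc1` gives 73%. Compound 2 `c1ccc(C2CCCCN2C2CCN(CCCc3c[nH]c4ccc(-n5cnnc5)cc34)CC2)cc1` gives 65%. Compound 3 `OC[C@H](NC1CCN(CCCc2c[nH]c3ccc(-n4ccnc4)cc23)CC1)c1ccccc1` gives 74%. The gap between compound 1 and compound 3 and the gap between compound 1 and compound 2 both lie within the usual scatter, so the three measured compounds are not distinguished by this assay.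

The next compound, compound 4 `CN(Cc1cccs1)C1CCN(CCCc2c[nH]c3ccc(-n4cnnc4)cc23)CC1`, differs from compound 1 in one place: methyl((thiophen-2-yl)methyl)amino in place of ((phenylsulfonyl)amino)methyl on a saturated ring carbon. Going by the values given here, no measured pair shows this change, so nothing is known of its effect on maximal response.

The three measured compounds carry quite different groups at this position and all sit within the scatter of one another, which is the only ground for an expectation. The step of a number 3 percentage points lower from compound 1 to compound 4 (within the scatter) is therefore expected to be small, with no preferred direction beyond the scatter. For compound 4 the estimated efficacy in this assay is 70%, with a range from 55% to 85%.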

Compound 4, largest response reached (reported as efficacy), in percent of the reference or control that the assay uses: 81%
Estimate against measurement, compound 4: 11 percentage points below, and the stated range covers the measured number.
By their numbers in this assay, from the lowest: compounds 2, 1, 3 and 4 (each within the scatter of the next, the first and the last beyond it).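

In this assay, the exchange of ((phenylsulfonyl)amino)methyl for methyl((thiophen-2-yl)methyl)amino on this saturated ring carbon gives a number 8 percentage points higher from compound 1 to compound 4 (within the scatter). Going by these compounds alone, this is the first direct one-place comparison at this position, and it shows no step beyond the scatter. The maximal response of this pair therefore does not depend on keeping the phenylsulfonyl group, the hydrogen-bond donor or the double bonds outside aromatic rings of the leaving group, and a five-membered aromatic ring with one hetero atom can stand in place of the six-membered aromatic ring of carbon only.

On these data alone, whether a carboxylic acid, a primary amine or a benzyl(methyl)amino group at this carbon would give a similar maximal response remains open. Nothing measured here explains the size of this step.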